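Aryl thiourea series: trifluoromethoxy replacing chloro on compound 1

The source may report more compounds than this note shows. Statements on the series, on what has been measured and on what is new or still open speak of the compounds shown alone.

Measured compounds:
compound 1 `CNC(=O)c1cc(Oc2cccc(NC(=S)Nc3ccc(Cl)cc3)c2)ccn1` 24100 nM
compound 2 `CC(C)NC(=O)c1cc(Oc2cccc(NC(=S)Nc3ccc(Cl)cc3)c2)ccn1` 21200 nM
compound 3 `CNC(=O)c1cc(Oc2cccc(NC(=S)Nc3ccc(F)c(F)c3)c2)ccn1` 33100 nM

In a functional assay on PC-3 cells (Homo sapiens) for cytotoxicity, read by MTT assay, with a stated time of 48 h (a lower number here means a stronger inhibitor, a higher number a weaker inhibitor), compound 1 gives 24100 nM, which places it second highest of the three numbers; its nearest neighbour is compound 2 and the furthest is compound 3, and both steps, a 1.1-fold lower number from compound 1 to compound 2 (0.06 log units; within the scatter) and a 1.4-fold higher number from compound 1 to compound 3 (0.14 log units; within the scatter), stay within the scatter. Compound 4 `CNC(=O)c1cc(Oc2cccc(NC(=S)Nc3ccc(OC(F)(F)F)cc3)c2)ccn1` has not yet been run in this assay. It differs from compound 1 by trifluoromethoxy in place of chloro on an aromatic carbon. Among the compounds with values here, the one measured step that touches the same part of the shared core is the exchange of the ring substituent, a 1.4-fold higher number from compound 1 to compound 3 (0.14 log units; within the scatter); the amide-side step a 1.1-fold lower number from compound 1 to compound 2 (0.06 log units; within the scatter) is also small. Neither step moved beyond the scatter, so no step beyond the scatter is expected in this assay for compound 4 either, in no particular direction. Compound 4 is therefore expected near 23000 nM, with a range of 9000 nM to 58000 nM. This estimate amounts to an expected step of a 1.0-fold lower number from compound 1 to compound 4 (0.02 log units; within the scatter).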

Compound 4, half-maximal inhibitory concentration: 34700 nM
For compound 4 the middle estimate is 1.5-fold (0.18 log units) below the measured one, and the stated range covers the measured number.
By their numbers in this assay, from the lowest: compounds 2, 1, 3 and 4 (each within the scatter of the next).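

In this assay, trifluoromethoxy in place of chloro on an aromatic carbon, para to a large group, gives a 1.4-fold higher number from compound 1 to compound 4 (0.16 log units; within the scatter): a group of 5 heavy atoms with 1 hydrogen-bond acceptor replaces a single chlorine without a step beyond the scatter. With a 1.4-fold higher number from compound 1 to compound 3 (0.14 log units; within the scatter) for 3,4-difluorophenyl in place of 4-chlorophenyl, both exchanges shown on this ring stay within the scatter, and neither compound 3 nor compound 4 goes against this. No measurement is at hand that would account for this result.

Open, going by these compounds, is whether an amine or a carboxylic acid at this position, or a longer chain on the amide-type nitrogen, would give a step beyond the scatter. Also open, on these data alone, is whether the trifluoromethoxy exchange behaves the same way outside this assay.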